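Fluoro for methoxy: expected shift in growth inhibition

This account rests on a few compounds, and the source may have more. Where it says the series, first, only, none or still open, it means among the compounds named here.

Of the compounds shown here, two carry numbers so far. Compound 1 `COc1ccc(-c2ccc(-c3ccc(C(=N)N)cc3)s2)cc1` bears a methoxy group; in a functional assay on T47D cells (Homo sapiens) for inhibition, read by sulforhodamine B assay, with a stated time of 48 h (on this read-out higher numbers stand for weaker inhibition of growth and lower numbers for stronger inhibition of growth), compound 1 gives 300 nM, the lowest of the two numbers. Compound 2 `N=C(N)c1ccc(-c2ccc(-c3cc(Cl)cc(Cl)c3)s2)cc1` gives 1480 nM in this assay, a higher number than compound 1 and beyond the usual scatter; the two differ at more than one point, so no single change can be read from that pair. Compound 3 `N=C(N)c1ccc(-c2ccc(-c3ccc(F)cc3)s2)cc1` is not yet measured. Relative to compound 1 the change is fluoro in place of methoxy on an aromatic carbon. Among the compounds with values here, no measured pair shows this change on its own, so the expectation rests only on the two numbers in hand. For compound 3 the expected step in this assay is a 1.7-fold higher number from compound 1 to compound 3 (0.22 log units; within the scatter), a small move toward weaker inhibition, near the edge of the scatter. Compound 3 is estimated at 500 nM, with a range from 150 nM to 1600 nM.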

Compound 3, concentration for 50% growth inhibition: 1200 nM
Compound 3: the middle estimate sits 2.4-fold (0.38 log units) below what was measured; low and high end bracket the measured number.
By their numbers in this assay, from the lowest: compound 1; then compounds 3 and 2 (each within the scatter of the next).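

In this assay, fluoro in place of methoxy on an aromatic carbon, para to a large group, now has a measured effect of its own: a 4.0-fold higher number from compound 1 to compound 3 (0.60 log units; beyond the scatter), a move toward weaker inhibition of growth. The position is therefore sensitive to the group it carries, and of these two groups, methoxy goes with the lower number, something the comparison of compound 1 with compound 2 could not show, as that pair differs at more than one point. No available measurement accounts for the step.

One pair cannot separate what is lost with methoxy from what fluoro brings. On these data alone, whether an amine, a hydroxy group or a longer alkoxy chain at this place would stay close to compound 1 or fall nearer compound 3 remains open.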